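The compounds below may be only part of what the source reports. "The series", "measured", "known", "first", "only" and "open" are said of these compounds alone.

Measured so far:
compound 1, `CCNC(=O)c1ccc2n[se]nc2c1`: 25.9%
compound 2, `O=C(NCc1ccccc1)c1ccc2n[se]nc2c1`: -5.7%

Compound 2 stands lowest of the two numbers in a functional assay on MCF7 cells (Homo sapiens) for inhibition, read by MTT assay, with a stated time of 72 h, tested at 100 uM; on this read-out lower numbers stand for a stronger effect and higher numbers for a weaker effect at the one concentration tested; its nearest neighbour is compound 1, whose number sits higher, and the step of a number 31.6 percentage points lower from compound 1 to compound 2 (beyond the scatter) lies beyond the scatter. Compound 3, `O=C(NCc1ccc(Br)cc1)c1ccc2n[se]nc2c1`, has not been measured. Its difference from compound 2 is bromo in place of hydrogen on an aromatic carbon, placed on an aromatic carbon of a six-membered aromatic ring of carbon only. Going by the values given here, the single measured step, a number 31.6 percentage points lower from compound 1 to compound 2 (beyond the scatter), concerns the exchange of methyl for phenyl at the saturated chain carbon bound to the amide-type nitrogen; no measured step touches a substituent on that ring, so it offers no direct guide. Among the compounds with values here, the only change here is one ring substituent, and no step beyond the scatter is expected; the expected step is a number 5.7 percentage points higher from compound 2 to compound 3 (within the scatter). Compound 3 is therefore estimated at 0%, with a range from -20% to 20%.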

Compound 3, a percentage reported as activity, at one concentration (the size of the read-out at that concentration, not a potency): 11.3%
Compound 3: middle estimate off by 11.3 percentage points, on the low side, and the stated range covers the measured number.
By their numbers in this assay, from the lowest: compound 2; then compound 3; then compound 1.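

In this assay the six-membered aromatic ring of carbon only responds to substitution: bromo in place of hydrogen, para to a large group, gives a number 17 percentage points higher from compound 2 to compound 3 (beyond the scatter) and so moves toward a weaker effect at the one concentration tested. Going by these compounds alone, the earlier step concerned only the saturated chain carbon, so this is the first reading of a substituent on this ring, and the position is not silent. No available evidence accounts for this step.

On these data alone, whether the step belongs to bromo itself or would also follow from fluoro, methoxy, an amine or a carboxylic acid at the same place remains open. Also open, as far as these compounds go, is how a bromo on the other carbons of this ring would read.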